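Hydroxymethyl for formyl on a tricyclic acid scaffold

The compounds below may be only part of what the source reports. "The series", "measured", "known", "first", "only" and "open" are said of these compounds alone.

Compound 1, `C[C@@H]1CC[C@H]2CC3=C(C(=O)O)CC[C@@]31C2(C)C`: 26000 nM
Compound 2, `COC(=O)C1=C2C[C@@H]3CC[C@@H](C)[C@]2(CC1)C3(C)C`: 26000 nM
Compound 3, `C[C@@H]1CC[C@H]2CC3=C(C=O)CC[C@@]31C2(C)C`: 26000 nM

The three measured compounds were tested in an ADME assay on HepG2 cells (Homo sapiens) for cytotoxicity, read by CellTiter-Glo, with a stated time of 72 h (on this read-out higher numbers stand for an effect only at larger amounts of compound and lower numbers for an effect already at smaller amounts), and all return the same reading. Compound 3 stands level with compound 1 and compound 2 at the digits shown; the nearest to it is compound 1 and the furthest is compound 2, with no difference beyond the scatter in either case. The steps among them bear on what happens at the carbonyl carbon of the shared core: no change at the digits printed from compound 1 to compound 2 (within the scatter) for methyl in place of hydrogen on an oxygen next to a carbonyl group, no change at the digits printed from compound 1 to compound 3 (within the scatter) for hydrogen in place of hydroxy on a carbonyl carbon, and no change at the digits printed from compound 2 to compound 3 (within the scatter) for hydrogen in place of methoxy on a carbonyl carbon.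

Compound 4, `C[C@@H]1CC[C@H]2CC3=C(CO)CC[C@@]31C2(C)C`, has not yet been measured. Its difference from compound 3 is hydroxymethyl in place of formyl on a double-bonded ring carbon. Going by the values given here, since every change at this position so far left this assay unmoved, no step beyond the scatter is expected in either direction: no change at the digits printed from compound 3 to compound 4 (within the scatter). Compound 4 is therefore estimated at 26000 nM, within 13000 nM to 52000 nM.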

Compound 4, half-maximal effective concentration: 26000 nM
Estimate against measurement, compound 4: no gap at the digits printed; the range from low to high includes it.
By their numbers in this assay, from the lowest: compounds 1, 2, 3 and 4 (each within the scatter of the next).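

In this assay hydroxymethyl in place of formyl gives no change at the digits printed from compound 3 to compound 4 (within the scatter) and hydroxymethyl in place of methoxycarbonyl gives no change at the digits printed from compound 2 to compound 4 (within the scatter) while hydroxymethyl in place of carboxy gives no change at the digits printed from compound 1 to compound 4 (within the scatter) on the same double-bonded ring carbon. Going by these compounds alone, compounds 1, 2 and 3 all carry a carbonyl group at this place, so compound 4 is the first to show that the reading holds without one, and none of the four compounds goes against this. Against compound 3, the change also removes the double bond of the formyl group and brings in a hydrogen-bond donor, and neither alters the reading at the digits printed; nothing at hand explains this. The compounds shown leave open whether an amine or a longer chain at this place would move the reading. They also leave open whether changes elsewhere on the shared core would do so.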